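Swapping Chloro for Bromo on the Sulfonyl Aryl Ring

A few compounds are considered here, and "the series" means these few. Any claim that something is new, unique, unknown or untested is made for them only; others in the source may bear on it.

Of the compounds shown here, three sharing one core have been tested in a functional assay on SMMC-7721 cells (Homo sapiens) for antiproliferative activity, read by MTT assay, with a stated time of 72 h; a lower number here means a stronger inhibitor, a higher number a weaker inhibitor. Compound 1 `CN(C(=O)CCc1ccccc1)c1ccc2[nH]c(-c3n[nH]c4ccccc34)cc2n1` gives 20900 nM. Compound 2 `CN(C(=O)c1ccco1)c1ccc2[nH]c(-c3n[nH]c4ccccc34)cc2n1` gives 28200 nM in this assay. Compound 3 `CN(c1ccc2[nH]c(-c3n[nH]c4ccccc34)cc2n1)S(=O)(=O)c1ccc(Cl)cc1` gives 12700 nM in this assay, the lowest of the three numbers; its step from compound 1 is a 1.6-fold lower number from compound 1 to compound 3 (0.22 log units; within the scatter), so those two sit within the scatter of each other, while a 2.2-fold lower number from compound 2 to compound 3 (0.35 log units; beyond the scatter) is a modest step beyond it.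

Compound 4 `CN(c1ccc2[nH]c(-c3n[nH]c4ccccc34)cc2n1)S(=O)(=O)c1ccc(Br)cc1` has yet to be measured. It differs from compound 3 in one place: bromo in place of chloro on an aromatic carbon. Within the data shown here, none of the measured steps alters a halogen on the aryl ring of the (4-chlorophenyl)sulfonyl group; the two steps that reach compound 3 each replace the entire group on the aromatic nitrogen, and even those larger changes moved the number only by the amounts just given. A swap of one halogen for another at the same place is a smaller change than either, so the step of a 1.2-fold lower number from compound 3 to compound 4 (0.06 log units; within the scatter) is expected to stay within the scatter, with no direction that can be read from these data. Compound 4 is therefore estimated to give 11000 nM in this assay, with a range from 5000 nM to 25000 nM.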

Compound 4, half-maximal inhibitory concentration: 11500 nM
Compound 4: the middle estimate sits 1.0-fold (0.02 log units) below what was measured; low and high end bracket the measured number.
By their numbers in this assay, from the lowest: compounds 4, 3, 1 and 2 (each within the scatter of the next, the first and the last beyond it).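

Among these compounds, this is the first change confined to the halogen on the sulfonyl aryl ring, and in this assay the exchange of chloro for bromo, para to a large group, stays within the scatter (a 1.1-fold lower number from compound 3 to compound 4 (0.04 log units; within the scatter)), so the two halogens cannot be told apart at this position. The bromo compound also keeps the standing of its chloro partner against the two carbonyl compounds, with a modest step beyond the scatter on one side (a 2.5-fold lower number from compound 2 to compound 4 (0.39 log units; beyond the scatter)) and a step within the scatter on the other (a 1.8-fold lower number from compound 1 to compound 4 (0.26 log units; within the scatter)). No independent information is available here to explain why this exchange leaves the number within the scatter.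

The compounds shown carry only chloro or bromo on this aromatic carbon, so it remains open whether the same tolerance would hold for an amine, a carboxylic acid, a methoxy group or a plain hydrogen there. From the compounds shown here alone, it also remains open whether a longer chain on the nitrogen in place of the methyl group would alter the number for either halogen.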